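Amide-side variations on a shared fluorinated core

The source may hold more compounds than are shown below. What is called first, only, known or untested is meant among the compounds shown, and "the series" means these compounds.

Measured so far:
compound 1 `CC1=C(C(C)C(=O)NCCN2CCCCC2)c2cc(F)ccc2/C1=C\c1ccc([S+](C)[O-])cc1` gives 39300 nM in a functional assay on MDA-MB-231 cells (Homo sapiens) for inhibition, read by CellTiter-Glo, with a stated time of 96 h; a lower number here means that less compound is tolerated, a higher number that more compound is tolerated
compound 2 `CC1=C(C(C)C(=O)NCCN2CCNCC2)c2cc(F)ccc2/C1=C\c1ccc([S+](C)[O-])cc1` gives > 50000 nM in this assay, a limit
compound 3 `CC1=C(C(C)C(=O)N2CCN(CCCN(C)C)CC2)c2cc(F)ccc2/C1=C\c1ccc([S+](C)[O-])cc1` gives > 50000 nM in this assay, a limit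

Compound 3 stands at a limit, not a number, in this assay; only compound 1 yields a number. The next change gives compound 4 `CC1=C(C(C)C(=O)N2CCN(c3ccncc3)CC2)c2cc(F)ccc2/C1=C\c1ccc([S+](C)[O-])cc1`, that is pyridin-4-yl in place of 3-(dimethylamino)propyl on an amine nitrogen in a ring.

Bearing on it are an at least 1.2-fold higher number from compound 1 to compound 3 (0.10 log units; that floor lies within the scatter) and a step that the two limits leave unreadable from compound 2 to compound 3. Both end at the same floor, (the limit of > 50000 nM in this assay, at which 2 of the 3 values shown sit), so no direction beyond the scatter can be read for changes on this side of the core.

Compound 4 is therefore expected to sit at the limit as well, estimated at 50000 nM within 20000 nM to 50000 nM. The expected step is a number no higher from compound 3 to compound 4 (the limit leaves the size open).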

Compound 4, half-maximal cytotoxic concentration: 19600 nM
For compound 4 the middle estimate is 2.6-fold (0.41 log units) above the measured one; measured number below the stated range.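

In this assay, the group on the amine nitrogen in the ring now makes a readable difference: pyridin-4-yl in place of 3-(dimethylamino)propyl gives an at least 2.5-fold lower number from compound 3 to compound 4 (0.40 log units; beyond the scatter). Against the open-chain amide with its piperazin-1-yl group there is an at least 2.5-fold lower number from compound 2 to compound 4 (0.40 log units; beyond the scatter), while the comparison with the piperidin-1-yl amide gives a 2.0-fold lower number from compound 1 to compound 4 (0.30 log units; within the scatter), which separates nothing. The first two steps are floors, set by the limit: the limit of > 50000 nM in this assay, at which 2 of the 4 values shown sit.

Whether the aromatic ring alone or its ring nitrogen accounts for the step remains open. Phenyl or pyridin-3-yl on the same nitrogen would separate the two.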